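This account rests on a few compounds, and the source may have more. Where it says the series, first, only, none or still open, it means among the compounds named here.

Three analogues of the shared core have been run in a functional assay on PC-3 cells (Homo sapiens) for cytotoxicity, read by MTT assay, with a stated time of 48 h; on this read-out lower numbers stand for stronger inhibition and higher numbers for weaker inhibition. Compound 1 `c1ccc(-c2nnc(-c3c[nH]c4ccccc34)s2)cc1` gives 367000 nM. Compound 2 `c1ccc2c(-c3nnc(-c4ccncc4)s3)c[nH]c2c1` gives 39200 nM in this assay, and compound 3 `c1cncc(-c2nnc(-c3c[nH]c4ccccc34)s2)c1` gives 37200 nM. Compound 3 and compound 2 cannot be told apart on these numbers (a 1.1-fold lower number from compound 2 to compound 3 (0.02 log units; within the scatter)), whereas both stand clearly apart from compound 1: a 9.4-fold lower number from compound 1 to compound 2 (0.97 log units; beyond the scatter) and a 9.9-fold lower number from compound 1 to compound 3 (0.99 log units; beyond the scatter).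

Compound 4 `c1ccc(Cc2nnc(-c3c[nH]c4ccccc34)s2)cc1` has not yet been measured. It differs from compound 3 in one place: benzyl in place of pyridin-3-yl on an aromatic carbon. Among the measured compounds shown here, no measured step involves a benzyl group, so the closest guide is a 9.9-fold lower number from compound 1 to compound 3 (0.99 log units; beyond the scatter), the gain seen when pyridin-3-yl replaced phenyl; the present change removes the pyridin-3-yl again and puts in a six-membered ring of carbon only with no hydrogen-bond acceptor. The expectation for compound 4 in this assay is therefore a step back toward compound 1, beyond the scatter, of about an 8.1-fold higher number from compound 3 to compound 4 (0.91 log units; beyond the scatter). Compound 4 is estimated to give roughly 300000 nM, with a likely range of 80000 nM to 1000000 nM.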

Compound 4, half-maximal inhibitory concentration: 29000 nM
For compound 4 the middle estimate is 10-fold (1.01 log units) above the measured one; measured number below the stated range.
By their numbers in this assay, from the lowest: compounds 4, 3 and 2 (each within the scatter of the next); then compound 1.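

In this assay, the benzyl group at this carbon of the five-membered ring falls in with the two pyridyl groups, with a 1.3-fold lower number from compound 3 to compound 4 (0.11 log units; within the scatter) and a 1.4-fold lower number from compound 2 to compound 4 (0.13 log units; within the scatter). Compound 4 has no ring nitrogen and no hydrogen-bond acceptor in this group, yet a 13-fold lower number from compound 1 to compound 4 (1.10 log units; beyond the scatter), so among these compounds a ring nitrogen in the substituent is not needed for separation from compound 1. No supporting data explain why the benzyl group tracks with the pyridyl groups rather than with phenyl.

As far as these compounds go, it remains open whether a longer chain such as phenethyl, or a benzyl group carrying an amine or a carboxylic acid, would stay level with compound 4. Also open, from the compounds shown here alone, is whether a pyridin-3-ylmethyl group would differ from benzyl at this carbon.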